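A few compounds are considered here, and "the series" means these few. Any claim that something is new, unique, unknown or untested is made for them only; others in the source may bear on it.

Measured in a functional assay on A549 cells (Homo sapiens) for cytotoxicity, read by MTT assay, with a stated time of 4 days; on this read-out higher numbers stand for weaker inhibition and lower numbers for stronger inhibition:
Compound 1 `Cc1ccc(S(=O)(=O)Oc2ccc3c(c2C)[C@H](Cn2cc(-c4ccccn4)nn2)[C@@]24CC(=O)[C@@](C)(CC[C@@H]32)C4)cc1`: > 20000 nM (a limit of the assay)
Compound 2 `COc1ccc(-c2cn(C[C@H]3c4c(ccc(OS(=O)(=O)c5ccc(C)cc5)c4C)[C@@H]4CC[C@@]5(C)C[C@]43CC5=O)nn2)cc1`: > 20000 nM (a limit of the assay)
Compound 3 `C=C1C[C@]23C[C@@]1(O)CC[C@@H]2c1cccc(C)c1[C@@H]3Cn1cc(-c2ccc(C(F)(F)F)cc2)nn1`: > 20000 nM (a limit of the assay)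

In this assay compound 2 gives > 20000 nM, which is a limit of the assay and not a number. In this assay compound 1 likewise gives only the limit > 20000 nM. Compound 3, built on a different core, gives in this assay the limit > 20000 nM. Going by the values given here, the only step between measured compounds that differ in one place, a step that the two limits leave unreadable from compound 1 to compound 2, cannot be read, since both ends sit at the limit; this is the situation summarised by the limit of > 20000 nM in this assay, at which 3 of the 3 values shown sit.

Compound 4 `Cc1ccc(S(=O)(=O)Oc2ccc3c(c2C)[C@H](Cn2cc(-c4ccc(C(F)(F)F)cc4)nn2)[C@@]24CC(=O)[C@@](C)(CC[C@@H]32)C4)cc1` is not yet measured. It differs from compound 2 in one place: trifluoromethyl in place of methoxy on an aromatic carbon. Among the compounds with values here, no measured step bears directly on this change, and every value shown sits at the same limit, so nothing in these data points to a step in either direction beyond the scatter in this assay. The expected step from compound 2 is therefore a step that the limit leaves unreadable from compound 2 to compound 4, taken as no real change. For compound 4 the estimate in this assay is 30000 nM, within 12000 nM to 80000 nM, with a limit as the most likely report.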

Compound 4, half-maximal inhibitory concentration: > 20000 nM
Compound 4: only a limit was reported; the forecaster's own chance of this, stated with the estimate: 85%; the middle value does not contradict the limit.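

In this assay compound 4 gives > 20000 nM, a limit of the assay and not a number. The steps to compound 4 from compound 1 and compound 2 cannot be read, because all these compounds sit at one limit: the limit of > 20000 nM in this assay, at which 4 of the 4 values shown sit.

The compounds shown leave open whether any of these aromatic groups changes the cytotoxicity in this assay.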